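Working notes: from compound 3 to compound 4

The source may hold more compounds than are shown below. What is called first, only, known or untested is meant among the compounds shown, and "the series" means these compounds.

Measured in an ADME assay on MDBK cells (Bos taurus) for cytotoxicity; a lower number here means that less compound is tolerated, a higher number that more compound is tolerated:
- compound 1 `COc1cccc(Cn2ccc3nc(-c4ccccc4)nc-3c2)c1`: > 100000 nM
- compound 2 `Clc1ccccc1Cn1ccc2nc(-c3ccccc3)nc-2c1`: > 100000 nM
- compound 3 `Clc1cccc(Cn2ccc3nc(-c4ccccc4)nc-3c2)c1`: > 100000 nM

All three entries are limits, not numbers. Compound 3 stands at > 100000 nM, and this too is only a limit.

Compound 4 `N#Cc1ccccc1Cn1ccc2nc(-c3ccccc3)nc-2c1` has 2-cyanophenyl in place of 3-chlorophenyl on a saturated chain carbon bound to an aromatic nitrogen.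

For the measured compounds named here, the steps that bear on this change are a step that the two limits leave unreadable from compound 1 to compound 2, a step that the two limits leave unreadable from compound 1 to compound 3 and a step that the two limits leave unreadable from compound 2 to compound 3. None has a readable size, and the series shows only (the limit of > 100000 nM in this assay, at which 3 of the 3 values shown sit). No step beyond the scatter is therefore expected in this assay, and no direction can be assigned. The expected step is a number no higher from compound 3 to compound 4 (the limit leaves the size open). The estimate for compound 4 is 100000 nM, with an expected range of 40000 nM to 250000 nM.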

Compound 4, half-maximal cytotoxic concentration: > 100000 nM
Compound 4 ended at the assay's limit; the forecaster's own chance of this, stated with the estimate: 80%; the middle value sits exactly at the limit.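

In this assay compound 4 gives > 100000 nM, again a limit and not a number, and the steps to it from compound 1, compound 2 and compound 3 cannot be read. The compounds shown leave open whether any of these aromatic groups alters what is tolerated in this assay.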